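Trading 3,5-difluorophenyl for 4-fluorophenyl on a sulfonyl sulfur

The source may report more compounds than this note shows. Statements on the series, on what has been measured and on what is new or still open speak of the compounds shown alone.

- compound 1 `O=C(NCc1ccc(S(=O)(=O)c2cc(F)cc(F)c2)cc1)c1cc2cnccc2[nH]1` gives 82%
- compound 2 `O=C(NCc1ccc(S(=O)(=O)c2cc(F)cc(F)c2)cc1)c1cnc2nccn2c1` gives 78%
- compound 3 `O=C(NCc1ccc(S(=O)(=O)c2cc(F)cc(F)c2)cc1)c1cc2ccncc2o1` gives 77%

All three compounds were tested in an ADME assay on microsomes from liver (Homo sapiens) for metabolic stability, read by LC-MS, with a stated time of 30 min, tested at 1 uM (on this read-out higher numbers stand for a more stable compound and lower numbers for a less stable compound), and their values lie close together. Compound 1, at 82%, stands within the scatter of both others. The direct comparisons show a number 4 percentage points lower from compound 1 to compound 2 (within the scatter) and a number 5 percentage points lower from compound 1 to compound 3 (within the scatter), so neither step separates the compounds.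

Compound 4 `O=C(NCc1ccc(S(=O)(=O)c2ccc(F)cc2)cc1)c1cc2cnccc2[nH]1` keeps the core of compound 1 and alters one group: 4-fluorophenyl in place of 3,5-difluorophenyl on a sulfonyl sulfur. In words, 4-fluorophenyl sits in place of 3,5-difluorophenyl on a sulfonyl sulfur.

For the measured compounds named here, none of the measured steps touches that group. Each one exchanges the group on a carbonyl carbon, so they give no direct measure of this change. They show only that, in this small set, changing another part of the molecule left the value within the scatter, as in a number 4 percentage points lower from compound 1 to compound 2 (within the scatter) and a number 5 percentage points lower from compound 1 to compound 3 (within the scatter). With so little evidence, no step beyond the scatter is expected in this assay, and a small drop is only a cautious guess. The estimated step is a number 5 percentage points lower from compound 1 to compound 4 (within the scatter) and it carries wide uncertainty. For compound 4 the expected value is 77%, with an estimated range from 62% to 90%.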

Compound 4, percent of the compound remaining: 91%
Estimate against measurement, compound 4: 14 percentage points below, outside the stated range (above it).
By their numbers in this assay, from the lowest: compounds 3, 2, 1 and 4 (each within the scatter of the next, the first and the last beyond it).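

Here, for the first time, the change falls on the group on the sulfonyl sulfur and not on the group on a carbonyl carbon: in this assay the exchange of 3,5-difluorophenyl for 4-fluorophenyl gives a number 9 percentage points higher from compound 1 to compound 4 (within the scatter) and so does not separate the two compounds. With the core of compound 1 held fixed, this position accepts either fluorinated phenyl ring without a step beyond the usual scatter, which is a statement about this one pair and not a general rule. Nothing at hand explains this result.

For the compounds shown here, only this single pair speaks for the position, so it remains open whether the same exchange would give a similar step with the groups on the carbonyl carbon of compound 2 or compound 3. How much change the position accepts is also open: the compounds shown give no reading for a plain phenyl ring without fluorine, a methyl group, a longer alkyl chain or an amine on the sulfonyl sulfur.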